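Formyl in Place of Methylsulfonyl: Expected Binding Shift

The source may hold more compounds than are shown below. What is called first, only, known or untested is meant among the compounds shown, and "the series" means these compounds.

Measured so far in an assay on CHO cells for displacement of a labelled ligand from Alpha-2C adrenergic receptor (Homo sapiens); a lower number here means a stronger inhibitor, a higher number a weaker inhibitor:
- Compound 1 `CC(Oc1ccccc1Br)C1=NCCN1` gives 282 nM.
- Compound 2 `CC(Oc1ccccc1S(C)(=O)=O)C1=NCCN1` gives 3800 nM.

Compound 2 stands at the higher of the two numbers in this assay, its nearest neighbour being compound 1. For the measured compounds named here, the one step joining them is a 13-fold higher number from compound 1 to compound 2 (1.13 log units; beyond the scatter), which shows that a change at this aromatic carbon can move the number a long way.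

Compound 3 `CC(Oc1ccccc1C=O)C1=NCCN1` is the next member, not yet measured. It differs from compound 2 in that (formyl in place of methylsulfonyl on an aromatic carbon). Going by the values given here, no measured step describes this exact exchange, so the only guide is the step from compound 1 to compound 2, which was large. Formyl carries fewer heavy atoms and one fewer hydrogen-bond acceptor than methylsulfonyl, and it is reasonable to expect the number for compound 3 to settle between those of compound 1 and compound 2, which is to say a moderate step downward, estimated as a 3.2-fold lower number from compound 2 to compound 3 (0.50 log units; beyond the scatter). For compound 3 in this assay the expected value is 1200 nM, with a range from 300 nM to 5000 nM.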

Compound 3, inhibition constant: 8710 nM
The estimate for compound 3 lay 7.3-fold (0.86 log units) below the measured number, outside the stated range (above it).
By their numbers in this assay, from the lowest: compound 1; then compound 2; then compound 3.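

In this assay, putting formyl in place of methylsulfonyl on this aromatic carbon gives a 2.3-fold higher number from compound 2 to compound 3 (0.36 log units; beyond the scatter), so the group with fewer heavy atoms and fewer hydrogen-bond acceptors does not bring the number back toward that of compound 1. Set against bromo, formyl gives a 31-fold higher number from compound 1 to compound 3 (1.49 log units; beyond the scatter), which stands alongside a 13-fold higher number from compound 1 to compound 2 (1.13 log units; beyond the scatter) and shows that two quite different groups at this place both leave the number far higher than bromo does, with compound 1 the lowest of the three. Nothing available accounts for this order, and no separate measurement bears on it.

The three compounds leave open whether bromo is unusual at this place or whether other groups, such as chloro, methyl, methoxy, an amine or a carboxylic acid, would give numbers as low as that of compound 1 or lower. They also leave open whether the order of bromo, methylsulfonyl and formyl would hold with any other change to the shared core.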